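From methyl to chloro in compound 3

A few compounds are considered here, and "the series" means these few. Any claim that something is new, unique, unknown or untested is made for them only; others in the source may bear on it.

Compound 1 `COc1c(-c2ccc(C(F)(F)F)cc2Cl)ccc2nn([C@@H](CC(C)C)c3ccc(C(=O)NCCC(=O)O)cc3)cc12` gives 76%
Compound 2 `Cc1cc(C(F)(F)F)ccc1-c1ccc2nn([C@@H](CC(C)C)c3ccc(C(=O)NCCC(=O)O)cc3)cc2c1C` gives 64%

In an ADME assay on microsomes from liver (Canis lupus familiaris) for metabolic stability, with a stated time of 10 min, tested at 1 uM (a higher number here means that more of the compound is left, a lower number that less of the compound is left), compound 2 stands lowest of the two at 64% and its gap to compound 1 lies beyond the scatter. Compound 3 `Cc1c(-c2ccc(C(F)(F)F)cc2Cl)ccc2nn([C@@H](CC(C)C)c3ccc(C(=O)NCCC(=O)O)cc3)cc12` alters compound 2 in one place: chloro in place of methyl on an aromatic carbon puts chloro in place of methyl on an aromatic carbon, turning 2-methyl-4-(trifluoromethyl)phenyl into 2-chloro-4-(trifluoromethyl)phenyl. Compound 1 also carries this chloro group and gives 76% but differs elsewhere too, so only a small rise is expected. In this assay the estimated step is a number 6 percentage points higher from compound 2 to compound 3 (within the scatter) and stays within the scatter. For compound 3 the estimate is 70% with 58% to 82% as the expected range.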

Compound 3, percent of the compound remaining: 75%
Compound 3: middle estimate off by 5 percentage points, on the low side, within the range that was stated.
By their numbers in this assay, from the lowest: compound 2; then compounds 3 and 1 (each within the scatter of the next).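

Turning 2-methyl-4-(trifluoromethyl)phenyl into 2-chloro-4-(trifluoromethyl)phenyl gives, in this assay, a number 11 percentage points higher from compound 2 to compound 3 (beyond the scatter) on its own, so this single swap of methyl for chloro can be read separately from other differences. Methyl in place of methoxy on an aromatic carbon gives a number 1 percentage points lower from compound 1 to compound 3 (within the scatter) and so does not separate those two groups in this test. Nothing measured here explains either step.

Still open, going by these compounds, is what a fluoro, a nitrile or an amine in place of the chloro would give. Also open, on these data alone, is whether the swap of methyl for chloro gives a similar step when methoxy sits on the core.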